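The source may hold more compounds than are shown below. What is called first, only, known or untested is meant among the compounds shown, and "the series" means these compounds.

Measured in an ADME assay on GES1 cells (Homo sapiens) for inhibition, read by MTT assay, with a stated time of 72 h; on this read-out higher numbers stand for weaker inhibition and lower numbers for stronger inhibition:

Compound 1, `Cc1cc(Nc2cc(-c3ccccc3)[nH]n2)n2nc(SCc3ccc([N+](=O)[O-])cc3)nc2n1`: 43600 nM
Compound 2, `CCCCCc1c(C)nc2nc(SCc3ccc(Cl)cc3)nn2c1Nc1cc(-c2ccccc2)[nH]n1`: > 50000 nM
Compound 3, `Cc1cc(Nc2cc(-c3ccc(Cl)cc3)[nH]n2)n2nc(SCc3ccc(Br)cc3)nc2n1`: 28200 nM

Three compounds share one core and differ at the group carried on the sulfur-linked benzyl arm and at the substituents of the core. Compound 1 gives the highest of the two numbers in this assay, and its nearest neighbour is compound 3, whose number lies within the usual scatter of compound 1, so no order between the two can be read. For compound 2 the result is the limit of > 50000 nM in this assay, at which 1 of the 3 values shown sits, a limit of the assay and not a number.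

The next compound, compound 4, `Cc1cc(Nc2cc(-c3ccccc3)[nH]n2)n2nc(SCc3ccc(C(F)(F)F)cc3)nc2n1`, is compound 1 with trifluoromethyl in place of nitro on an aromatic carbon. For the measured compounds named here, no pair of measured compounds that differ in only one place is present, so the size of this change can be drawn from no measured step. All three measured values are weak or at the limit, and nothing among them marks the nitro group out as the cause of the number of compound 1. The step of a 1.0-fold lower number from compound 1 to compound 4 (0.02 log units; within the scatter) is therefore expected to be small, within the scatter, with some chance that only a limit is returned. Compound 4 is expected to give 42000 nM, between 15000 nM and 50000 nM.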

Compound 4, half-maximal inhibitory concentration: 42700 nM
Estimate against measurement, compound 4: 1.0-fold (0.01 log units) below; the range from low to high includes it.
By their numbers in this assay, from the lowest: compounds 3, 4 and 1 (each within the scatter of the next). At a limit, above all of these: compound 2.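

For the compounds shown here, the exchange of 4-nitrobenzyl for 4-(trifluoromethyl)benzyl gives the first step between compounds that differ in one place in this assay, and that step is a 1.0-fold lower number from compound 1 to compound 4 (0.01 log units; within the scatter), so no change can be read at this aromatic carbon. Nitro carries hydrogen-bond acceptors and trifluoromethyl carries none, yet on this read-out the two groups cannot be told apart at this place, for this pair alone. Nothing among the results shown offers a reason for this flat step.

Going by these compounds, the step covers only these two groups on an otherwise unchanged compound, so it remains open whether an amine, a carboxylic acid or a longer chain on the same aromatic carbon would also leave the number within the scatter. Compound 2 and compound 3 each differ from compound 1 in more than one place, so the steps to them cannot be read, and what the other substituents on the core and on the phenyl group contribute in this assay stays unresolved.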